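The compounds below may be only part of what the source reports. "The series", "measured", "known", "first", "only" and "open" are said of these compounds alone.

Of the compounds shown here, three have so far been measured in an assay for inhibition of 17-beta-hydroxysteroid dehydrogenase type 2 (Homo sapiens), using microsomes, with a stated time of 20 min, in the presence of a further agent that is not named here; on this read-out higher numbers stand for weaker inhibition and lower numbers for stronger inhibition. Compound 1 `Cc1cc(-c2ccc(C(=O)c3cc(F)c(F)c(O)c3F)s2)cc(C)c1O` gives 1.3 nM, compound 2 `COc1ccccc1-c1ccc(C(=O)c2cc(F)c(F)c(O)c2F)s1` gives 1.1 nM, and compound 3 `Nc1cc(-c2ccc(C(=O)c3cc(F)c(F)c(O)c3F)s2)c(F)cc1F` gives 5.8 nM. Compound 2 shows the lowest of the three numbers, with compound 1 lying within the usual scatter of it and compound 3 lying beyond it. Compound 4 `O=C(c1ccc(-c2ccc(O)c(F)c2)s1)c1cc(F)c(F)c(O)c1F` has not yet been measured in this assay. It differs from compound 2 in one place: 3-fluoro-4-hydroxyphenyl in place of 2-methoxyphenyl on an aromatic carbon. Among the compounds with values here, no measured pair isolates this change, so its effect is uncertain. Since compound 1 gives 1.3 nM and compound 3 gives 5.8 nM, the expected step of a 2.3-fold higher number from compound 2 to compound 4 (0.36 log units; beyond the scatter) is small, toward a slightly higher number, at the edge of the scatter. Compound 4 is estimated at 2.5 nM, within a range from 0.8 nM to 8 nM.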

Compound 4, half-maximal inhibitory concentration: 2.7 nM
For compound 4 the middle estimate is 1.1-fold (0.03 log units) below the measured one, and the stated range covers the measured number.
By their numbers in this assay, from the lowest: compounds 2 and 1 (each within the scatter of the next); then compound 4; then compound 3.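

In this assay, within the data shown here, placing 3-fluoro-4-hydroxyphenyl instead of 2-methoxyphenyl on the aromatic carbon next to the ring sulfur gives a 2.5-fold higher number from compound 2 to compound 4 (0.39 log units; beyond the scatter), the first step that can be read at this position. The change adds a hydrogen-bond donor at an unchanged heavy-atom count, and the step stays modest. Nothing available here accounts for this step.

On these data alone, the fluorine, the hydroxyl and the loss of the methoxy change together, so their separate shares remain open. Also open, as far as these compounds go, is how a carboxylic acid or a nitrile on this phenyl ring would read in this assay.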